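Ethyl in place of butyl, with every value at a limit

The source may hold more compounds than are shown below. What is called first, only, known or untested is meant among the compounds shown, and "the series" means these compounds.

Compound 1 `COC(=O)c1c[nH]c2cc(OCCOc3ccccc3)ccc2c1=O` carries hydrogen where compound 2 `COC(=O)c1c[nH]c2cc(OCCOc3ccccc3)c(C)cc2c1=O` carries methyl and compound 3 `CCCCc1cc2c(=O)c(C(=O)OC)c[nH]c2cc1OCCOc1ccccc1` carries butyl. In an ADME assay on J774 cells (Mus musculus) for cytotoxicity (a higher number here means that more compound is needed for the effect, a lower number that less compound is needed), compound 1 gives > 20000 nM, which is a limit and not a number. In this assay compound 2 gives > 20000 nM, again a limit. Compound 3 stands in the same place, with > 20000 nM, also only a limit.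

Compound 4 `CCc1cc2c(=O)c(C(=O)OC)c[nH]c2cc1OCCOc1ccccc1` has ethyl where compound 3 has butyl (hydrogen in place of ethyl on a saturated chain carbon, two bonds along the chain from an aromatic carbon).

Among the compounds with values here, three measured steps bear on this change: a step that the two limits leave unreadable from compound 1 to compound 2, a step that the two limits leave unreadable from compound 1 to compound 3 and a step that the two limits leave unreadable from compound 2 to compound 3. None of them has a readable size, so they give no direction, and the whole series rests on one line: the limit of > 20000 nM in this assay, at which 3 of the 3 values shown sit.

The expectation rests on a step that the two limits leave unreadable from compound 2 to compound 3, which joins methyl and butyl at the same limit, so no step beyond the scatter is expected for ethyl. The estimated step is a step that the limit leaves unreadable from compound 3 to compound 4. A further limit is the most likely report, and compound 4 is estimated at 25000 nM, with an expected range of 12000 nM to 50000 nM.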

Compound 4, half-maximal effective concentration: > 20000 nM
Compound 4 was reported as a limit (the forecaster's own chance of this, stated with the estimate: 90%); the middle value is on the limit's open side.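

Compound 4 joins compounds 1, 2 and 3 at a limit, so no step among these four compounds can be read: the limit of > 20000 nM in this assay, at which 4 of the 4 values shown sit.

The compounds shown leave open how the hydrogen, methyl, ethyl and butyl compounds differ in this assay, since none of them has a value that is an actual number.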